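The source may report more compounds than this note shows. Statements on the series, on what has been measured and on what is new or still open speak of the compounds shown alone.

Measured in a functional assay on MCF7 cells (Homo sapiens) for inhibition, read by sulforhodamine B assay; a lower number here means a stronger inhibitor, a higher number a weaker inhibitor:

- compound 1 `Cc1ccc(NC2=CC(=O)c3c(nc4n3[C@H]3OC[C@@H](O)[C@H]3OC4)C2=O)cc1` gives > 4000 nM
- compound 2 `O=C1C=C(Nc2cccc(F)c2)C(=O)c2c1nc1n2[C@H]2OC[C@@H](O)[C@H]2OC1` gives 5500 nM

Compound 1 has no number in this assay but only the limit > 4000 nM and that limit is where it stands. For the measured compounds named here, the one true number belongs to compound 2 at 5500 nM and it sets the level for the estimate below.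

Compound 3 `COc1ccc(NC2=CC(=O)c3c(nc4n3[C@H]3OC[C@@H](O)[C@H]3OC4)C2=O)cc1` differs from compound 1 by methoxy in place of methyl on an aromatic carbon. Going by the values given here, no measured pair shows this change. In this assay no shift beyond the scatter is expected in either direction, and the expected step that the limit leaves unreadable from compound 1 to compound 3 stays within it. Another limit instead of a number remains possible for compound 3. For compound 3 the estimated value is 5000 nM with an expected range from 2000 nM to 12000 nM in this estimate.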

Compound 3, half-maximal inhibitory concentration: 4470 nM
Compound 3: the middle estimate sits 1.1-fold (0.05 log units) above what was measured, within the range that was stated.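

No step can be read from compound 1 to compound 3, because compound 1 carries only a limit and not a number: the limit of > 4000 nM in this assay, at which 1 of the 3 values shown sits. The compounds shown leave open whether methoxy in place of methyl on an aromatic carbon shifts the value in this assay at all, and in which direction.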